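The source may report more compounds than this note shows. Statements on the series, on what has been measured and on what is new or still open speak of the compounds shown alone.

In a toxicity assay on HEK-293T cells (Homo sapiens) for cytotoxicity, read by MTT assay, with a stated time of 48 h (on this read-out higher numbers stand for weaker inhibition and lower numbers for stronger inhibition), compound 1 `C=C1[C@H](OC(C)=O)[C@@H](OC(C)=O)[C@@H](O)C(C)(C)/C=C/[C@H](C)[C@H](OC(=O)c2ccccc2)[C@@]2(O)C[C@@](C)(O)[C@H](OC(C)=O)[C@@H]2[C@H]1OCC(C)C` gives > 100000 nM, which is a limit of the assay and not a number. Within the data shown here, compound 2 `C=C1[C@H](OC(C)=O)[C@@H](OC(C)=O)[C@@H](OC(C)=O)C(C)(C)/C=C/[C@H](C)[C@H](OC(=O)c2ccccc2)[C@@]2(O)C[C@@](C)(O)[C@H](OC(C)=O)[C@@H]2[C@H]1OCC(C)C` gives 39300 nM, the only actual number so far. Compound 3 `C=C1[C@H](OC(C)=O)[C@@H](OC(=O)c2cccc(C)c2)[C@@H](OC(C)=O)C(C)(C)/C=C/[C@H](C)[C@H](OC(=O)c2ccccc2)[C@@]2(O)C[C@@](C)(O)[C@H](OC(C)=O)[C@@H]2[C@H]1OCC(C)C` differs from it by 3-methylphenyl in place of methyl on a carbonyl carbon, with 3-methylphenyl in place of methyl on a carbonyl carbon. Among the measured compounds shown here, the one measured step, an at least 2.5-fold lower number from compound 1 to compound 2 (0.40 log units; beyond the scatter), was a different change, adding an acetyl, so it offers only weak guidance. No shift beyond the scatter is therefore expected, and the estimated change is a 1.3-fold lower number from compound 2 to compound 3 (0.12 log units; within the scatter). For compound 3, the estimated value is 30000 nM, with an expected range of 10000 nM to 90000 nM.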

Compound 3, half-maximal inhibitory concentration: 4110 nM
Compound 3: middle estimate off by 7.3-fold (0.86 log units), on the high side; measured number below the stated range.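

In this assay the swap of acetyl for (3-methylphenyl)carbonyl on this oxygen gives a 9.6-fold lower number from compound 2 to compound 3 (0.98 log units; beyond the scatter) and so moves the read-out towards stronger cytotoxicity. This ester place on the shared core therefore responds to the group it carries, which the earlier step, made at a different oxygen, could not show. Among these compounds, nothing measured so far gives a cause for this step. Still open is how much the methyl on the new ring contributes, since the compounds shown do not separate it from the ring itself. A plain benzoyl or a longer chain such as hexanoyl at this place could show that.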